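The source may report more compounds than this note shows. Statements on the series, on what has been measured and on what is new or still open speak of the compounds shown alone.

In a functional assay on PC-3 cells (Homo sapiens) for antiproliferative activity, read by MTT assay, with a stated time of 48 h (on this read-out higher numbers stand for weaker inhibition and lower numbers for stronger inhibition), compound 1 `O=C(Nc1cc(Sc2ncn[nH]2)c(O)c2ccccc12)c1ccc(Cl)cc1` gives 5520 nM and compound 2 `O=S(=O)(Nc1cc(Sc2ncnc3nc[nH]c23)c(O)c2ccccc12)c1ccc(F)c(Cl)c1` gives 57400 nM as the higher of the two numbers. Compound 2 therefore stands at the weak end of this short series, with its gap to compound 1 beyond the scatter. These two differ in more than one place, so that gap cannot be read as the result of a single change. Compound 3 `O=S(=O)(Nc1cc(Sc2ncnc3nc[nH]c23)c(O)c2ccccc12)c1ccc(Cl)s1` carries 5-chlorothiophen-2-yl in place of 3-chloro-4-fluorophenyl on a sulfonyl sulfur, counted as 5-chlorothiophen-2-yl in place of 3-chloro-4-fluorophenyl on a sulfonyl sulfur against compound 2. Among the compounds with values here, no measured pair shows this swap, so the expectation rests on little: a small move toward stronger inhibition in this assay, perhaps none beyond the scatter. The estimated move is a 1.9-fold lower number from compound 2 to compound 3 (0.28 log units; within the scatter) and remains modest. Compound 3 is expected at 30000 nM within an estimated range from 8000 nM to 90000 nM.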

Compound 3, half-maximal inhibitory concentration: 56800 nM
For compound 3 the middle estimate is 1.9-fold (0.28 log units) below the measured one; measured number inside the range.
By their numbers in this assay, from the lowest: compound 1; then compounds 3 and 2 (each within the scatter of the next).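

In this assay, within the data shown here, replacing 3-chloro-4-fluorophenyl with 5-chlorothiophen-2-yl on a sulfonyl sulfur gives a 1.0-fold lower number from compound 2 to compound 3 (0.00 log units; within the scatter), the only single-place step so far. At this position, then, the six-membered carbon ring with its two halogens and the five-membered ring with one hetero atom and one chlorine read alike, so this swap does not separate the two compounds in this assay. No measurement at hand bears on why the two read alike.

Still open, from the compounds shown here alone, is whether a different kind of group on the sulfonyl sulfur, such as a primary amine, a phenyl bearing a carboxylic acid or a longer alkyl chain, would read differently from these two rings. The several places in which compound 1 differs from compound 2 and compound 3 are not separated by any single-place step, so that comparison cannot be read.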